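The compounds below may be only part of what the source reports. "The series", "measured", "known", "first", "only" and "open" are said of these compounds alone.

Compound 1 `N#CCC(=O)N/N=C1\C(=O)Nc2ccc(S(=O)(=O)N3CCOCC3)cc21`: 7530 nM
Compound 2 `O=C1Nc2ccc(S(=O)(=O)N3CCOCC3)cc2/C1=N/c1ccc(Cl)cc1`: 11800 nM
Compound 3 `CC(=O)N/N=C1\C(=O)Nc2ccc(S(=O)(=O)N3CCOCC3)cc21`: 27500 nM

All three were tested in a functional assay on HepG2 cells (Homo sapiens) for cytotoxicity, read by sulforhodamine B assay, with a stated time of 24 h; on this read-out lower numbers stand for stronger inhibition and higher numbers for weaker inhibition. Compound 3 gives the highest number of the three, with compound 2 nearest and compound 1 furthest. Compound 4 `O=C1Nc2ccc(S(=O)(=O)N3CCOCC3)cc2/C1=N/Nc1ccccc1` differs from compound 3 by phenyl in place of acetyl on an amine nitrogen. Within the data shown here, no measured pair carries exactly this change. The step that bears most on it is a 2.3-fold higher number from compound 2 to compound 3 (0.37 log units; beyond the scatter), where 4-chlorophenyl on the double-bonded nitrogen went with the lower number; a 3.7-fold higher number from compound 1 to compound 3 (0.56 log units; beyond the scatter) shows that the acetamido chain itself is sensitive to what is attached to it. A phenyl in place of acetyl is therefore expected to bring the number back down, a modest step of a 2.3-fold lower number from compound 3 to compound 4 (0.36 log units; beyond the scatter) in this assay. Compound 4 is expected to give 12000 nM in this assay, between 4000 nM and 36000 nM.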

Compound 4, half-maximal inhibitory concentration: 15600 nM
The estimate for compound 4 lay 1.3-fold (0.11 log units) below the measured number; the range from low to high includes it.
By their numbers in this assay, from the lowest: compounds 1, 2, 4 and 3 (each within the scatter of the next, the first and the last beyond it).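

In this assay, phenyl in place of acetyl on the amine nitrogen gives a 1.8-fold lower number from compound 3 to compound 4 (0.25 log units; within the scatter), so an aromatic ring of carbon only is taken up at this position without a step beyond the scatter. Anilino in place of 4-chlorophenyl on the double-bonded nitrogen gives a 1.3-fold higher number from compound 2 to compound 4 (0.12 log units; within the scatter), again within the scatter, whereas phenyl in place of (cyanomethyl)carbonyl gives a 2.1-fold higher number from compound 1 to compound 4 (0.32 log units; beyond the scatter), a step beyond it. Going by these compounds, what an amine or a carboxylic acid in place of phenyl on this nitrogen would give remains open. Nothing available explains these steps.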